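Series notes: 4-methylbenzyl in place of 2-fluorobenzyl

The source may report more compounds than this note shows. Statements on the series, on what has been measured and on what is new or still open speak of the compounds shown alone.

Among the compounds with values here, compound 3 `Cc1ccc(NC(=O)NC(=O)c2ccc(OCc3ccccc3F)cc2)cc1-c1nc2ccccc2[nH]1` gives 2520 nM in a functional assay on MGC-803 cells (Homo sapiens) for inhibition, read by MTT assay, with a stated time of 48 h (a higher number here means a weaker inhibitor, a lower number a stronger inhibitor), the lowest of the three numbers measured so far. Compound 1 `Cc1ccc(NC(=O)NC(=O)c2ccc(OCc3ccccc3)cc2)cc1-c1nc2ccccc2[nH]1` gives 39400 nM and compound 2 `Cc1ccc(NC(=O)NC(=O)c2ccc(OCc3cccc(Cl)c3)cc2)cc1-c1nc2ccccc2[nH]1` gives 20800 nM in this assay; the step of a 1.9-fold lower number from compound 1 to compound 2 (0.28 log units; within the scatter) stays within the scatter, whereas a 16-fold lower number from compound 1 to compound 3 (1.19 log units; beyond the scatter) and an 8.3-fold lower number from compound 2 to compound 3 (0.92 log units; beyond the scatter) both lie beyond it. Compound 4 `Cc1ccc(COc2ccc(C(=O)NC(=O)Nc3ccc(C)c(-c4nc5ccccc5[nH]4)c3)cc2)cc1` is not yet measured; it differs from compound 3 by 4-methylphenyl in place of 2-fluorophenyl on a saturated chain carbon bound to an oxygen on an aromatic ring. The step that bears most on this change is a 16-fold lower number from compound 1 to compound 3 (1.19 log units; beyond the scatter): compound 4, like compound 1, carries no fluorine on that ring. The step of a 1.9-fold lower number from compound 1 to compound 2 (0.28 log units; within the scatter) shows that the chloro of compound 2 left the number essentially where it was. The gain seen on going to compound 3 is therefore expected to be lost, and the number for compound 4 is expected to move back towards those of compound 1 and compound 2. The expected step is a 7.9-fold higher number from compound 3 to compound 4 (0.90 log units; beyond the scatter). Compound 4 is estimated at 20000 nM, with a range from 6000 nM to 50000 nM.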

Compound 4, half-maximal inhibitory concentration: 4250 nM
Compound 4: the middle estimate sits 4.7-fold (0.67 log units) above what was measured, outside the stated range (below it).
By their numbers in this assay, from the lowest: compounds 3 and 4 (each within the scatter of the next); then compounds 2 and 1 (each within the scatter of the next).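

In this assay, the step of a 1.7-fold higher number from compound 3 to compound 4 (0.23 log units; within the scatter) shows that 4-methylphenyl and 2-fluorophenyl cannot be told apart at this position, so a low number here is not confined to the fluoro compound. The step of a 9.3-fold lower number from compound 1 to compound 4 (0.97 log units; beyond the scatter) shows that a methyl in place of hydrogen on the aromatic carbon also counts, while the step of a 4.9-fold lower number from compound 2 to compound 4 (0.69 log units; beyond the scatter) separates 4-methylphenyl from 3-chlorophenyl, which stayed within the scatter of compound 1. No measurement bearing on the cause of these steps is available.

Compounds 3 and 4 differ in both the group and its place on the ring, so the compounds shown do not tell which of the two governs the number. On these data alone, how an amine or a carboxylic acid on this ring would read also remains open.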